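Two Triazolyl Spiro Compounds Against Breast Cancer Cells

This account rests on a few compounds, and the source may have more. Where it says the series, first, only, none or still open, it means among the compounds named here.

The study measured antiproliferative potency in a functional assay on MCF7 cells (Homo sapiens) for antiproliferative activity, read by MTT assay, with a stated time of 48 h; a lower number here means a stronger inhibitor, a higher number a weaker inhibitor. Compound 1 `Cc1ccc(Cl)cc1-n1nncc1CN1C(=O)C2(C(C#N)=C(N)Oc3c2c2nc4ccccc4nc2c2ccccc32)c2ccccc21` carries a 5-chloro-2-methylphenyl on an aromatic nitrogen of its triazole ring; in this assay compound 1 gives only a limit, > 50000 nM. Compound 2 `N#CC1=C(N)Oc2c(c3nc4ccccc4nc3c3ccccc23)C12C(=O)N(Cc1cnnn1-c1ccc(F)c(Cl)c1)c1ccccc12` differs from it by 3-chloro-4-fluorophenyl in place of 5-chloro-2-methylphenyl on an aromatic nitrogen. In this assay compound 2 likewise gives only a limit, > 50000 nM. Between the two, a step that the two limits leave unreadable from compound 1 to compound 2, since both sit at the limit of > 50000 nM in this assay, at which 2 of the 3 values shown sit.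

Compound 3 `Cc1ccc(Cl)cc1-n1nncc1CN1C(=O)C2(C(C#N)=C(N)Oc3c(N)cc4nc5ccccc5nc4c32)c2ccccc21` has a different core from compound 1; the difference between the two cores is not broken down here. Compound 3 is the only one of the three with a number rather than a limit: in this assay compound 3 gives 43500 nM.

Compound 4 `N#CC1=C(N)Oc2c(N)cc3nc4ccccc4nc3c2C12C(=O)N(Cc1cnnn1-c1ccc(F)c(Cl)c1)c1ccccc12` has not yet been measured in this assay. It differs from compound 3 by 3-chloro-4-fluorophenyl in place of 5-chloro-2-methylphenyl on an aromatic nitrogen, and the place of the change is described in the same words as for the pair of compound 1 and compound 2, so this is the same change, made a second time. The earlier instance of this change left no readable step, so there is no measured size to carry over. Compound 3 already lies close to the limit at which compound 1 and compound 2 sit, so the expected step from compound 3 to compound 4 is a 1.1-fold higher number from compound 3 to compound 4 (0.04 log units; within the scatter), with a real chance that only a limit is reported. Compound 4 is therefore expected to show about 48000 nM, within a range of 20000 nM to 120000 nM.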

Compound 4, half-maximal inhibitory concentration: 17800 nM
Compound 4: the middle estimate sits 2.7-fold (0.43 log units) above what was measured; the measured number lies below the stated range.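

On the second of the two cores, in this assay, putting 3-chloro-4-fluorophenyl in place of 5-chloro-2-methylphenyl on an aromatic nitrogen gives a 2.4-fold lower number from compound 3 to compound 4 (0.39 log units; beyond the scatter), a modest step but one that lies beyond the usual scatter of the measurement. On the other core the same change cannot be read, because compound 1 and compound 2 each give only a limit rather than a number: the limit of > 50000 nM in this assay, at which 2 of the 4 values shown sit. The change therefore has a measured size on one core alone, resting on a single pair in a single assay, so this result does not show that the step carries from one core to the other in either size or direction, and it gives no evidence that the effect depends on the core.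

The two aryl groups differ in more than one substituent, so the compounds shown leave open whether the chlorine, the fluorine or the loss of the methyl goes with the step. Also open, as far as these compounds go, is how a plain phenyl, or a phenyl carrying an amine or a carboxylic acid, would compare on the same core, and whether any such group would bring a number to the core of compound 1.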